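The source may report more compounds than this note shows. Statements on the series, on what has been measured and on what is new or still open speak of the compounds shown alone.

Compound 1, `CC(C)C[C@H](NC(=O)[C@H](NC(=O)c1cnccn1)C(C)C)B(O)O`, in an assay on isolated protein for inhibition of Lon protease homolog, mitochondrial (Homo sapiens), read by HTRF, with a stated time of 50 min, in the presence of a further agent that is not named here (on this read-out higher numbers stand for weaker inhibition and lower numbers for stronger inhibition), gives 546 nM. Compound 2, `CCC[C@@H](NC(=O)c1cnccn1)C(=O)N[C@@H](CC1CCCCC1)B(O)O`, in this assay gives 136 nM.

Of the two measured compounds, compound 2 has the lower number, and its distance from compound 1 is beyond the scatter. Compound 3, `CCCC[C@H](NC(=O)[C@@H](CCC)NC(=O)c1cnccn1)B(O)O`, differs from compound 2 by propyl in place of cyclohexyl on a saturated chain carbon, two bonds along the chain from an amide-type nitrogen and a boron atom. Going by the values given here, no measured pair shows this change. Because compound 2 gives 136 nM with the larger group, the smaller group is expected to give a weaker result, so compound 3 is expected to show a rise of a 2.9-fold higher number from compound 2 to compound 3 (0.47 log units; beyond the scatter). Compound 3 is estimated at 400 nM, within 150 nM to 1200 nM.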

Compound 3, half-maximal inhibitory concentration: 38 nM
For compound 3 the middle estimate is 11-fold (1.02 log units) above the measured one; the measured number lies below the stated range.
By their numbers in this assay, from the lowest: compound 3; then compound 2; then compound 1.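

In this assay the ring proves unnecessary at this position: propyl in place of cyclohexyl, on a saturated chain carbon two bonds along the chain from an amide-type nitrogen and a boron atom, gives a 3.6-fold lower number from compound 2 to compound 3 (0.55 log units; beyond the scatter), so here the smaller open chain outperforms the larger ring. This rests on a single pair, and no supporting data explain the step. Still open, going by these compounds, is whether a longer chain such as hexyl, a smaller ring such as cyclopentyl, or a terminal amine would keep or lose this gain at the same position.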